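Clearance after a 1,3-benzoxazol-5-yl swap on the shared core

The source may report more compounds than this note shows. Statements on the series, on what has been measured and on what is new or still open speak of the compounds shown alone.

Compound 1 `Nc1ccc(S(=O)(=O)N2CCN(c3ncc(C(O)(C(F)(F)F)C(F)(F)F)cc3C#CCO)CC2)cn1`: < 14 mL.min-1.g-1, a limit
Compound 2 `COc1cncc(-c2cc(C(O)(C(F)(F)F)C(F)(F)F)cnc2N2CCN(S(=O)(=O)c3ccc(N)nc3)CC2)c1`: 44 mL.min-1.g-1

Within the data shown here, in an ADME assay (liver) for metabolic stability, with Liver microsome (Homo sapiens) as the target, using microsomes and NADPH, with a stated time of 30 min, tested at 1 uM (a lower number here means slower removal, a higher number faster removal of the compound), compound 2 gives 44 mL.min-1.g-1, the only true number so far. Compound 1 stands at a limit, < 14 mL.min-1.g-1. Compound 3 `Nc1ccc(S(=O)(=O)N2CCN(c3ncc(C(O)(C(F)(F)F)C(F)(F)F)cc3-c3ccc4ocnc4c3)CC2)cn1` carries 1,3-benzoxazol-5-yl in place of 5-methoxypyridin-3-yl on the same aromatic carbon (1,3-benzoxazol-5-yl in place of 5-methoxypyridin-3-yl on an aromatic carbon). Among the measured compounds shown here, the one measured change at that carbon, an at least 3.1-fold higher number from compound 1 to compound 2 (0.49 log units; beyond the scatter), lies beyond the scatter, but it removed a different group, 3-hydroxyprop-1-yn-1-yl, and so offers only a loose guide. A change within the scatter is expected, leaning upward: a 1.3-fold higher number from compound 2 to compound 3 (0.12 log units; within the scatter). For compound 3 the estimate is 58 mL.min-1.g-1, with an expected range of 24 mL.min-1.g-1 to 130 mL.min-1.g-1.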

Compound 3, intrinsic clearance in microsomes: < 14 mL.min-1.g-1
Compound 3: only a limit was reported; the forecaster's own chance of this, stated with the estimate: 8%; middle value at least 4.1-fold (0.61 log units) away from the limit.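

At this aromatic carbon, 1,3-benzoxazol-5-yl in place of 5-methoxypyridin-3-yl brings an at least 3.1-fold lower number from compound 2 to compound 3 (0.49 log units; beyond the scatter) in this assay. An aromatic ring at this carbon therefore does not by itself go with the higher number seen for compound 2, and the identity of the ring matters. The step from compound 1 to compound 3 cannot be read, and the step to compound 3 has no upper size, as compound 3 is also a limit: the limit of < 14 mL.min-1.g-1 in this assay, at which 2 of the 3 values shown sit.

Which atoms of the 1,3-benzoxazol-5-yl group go with the lower number remains open. So does the reading for an amine or a carboxylic acid at this carbon.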